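Chloro in place of methoxy on the anilino ring

A few compounds are considered here, and "the series" means these few. Any claim that something is new, unique, unknown or untested is made for them only; others in the source may bear on it.

Compound 3 `COc1ccc(Nc2sc(C(=O)c3ccc(OC)cc3)c(C)c2C(=O)O)cc1` gives 32.5% in a functional assay, with a stated time of 150 min, tested at 20 ug/mL; a lower number here means a weaker effect, a higher number a stronger effect of the compound at the concentration tested. Among the numbers so far it stands lowest of two, the nearest being compound 2 `COc1ccc(C(=O)c2sc(Nc3ccccc3)c(C(=O)O)c2C)cc1`, which gives 41.2% in this assay; the step of a number 8.7 percentage points lower from compound 2 to compound 3 (within the scatter) is within the scatter, so the two cannot be ordered. Compound 1 `COC(=O)c1c(Nc2ccc(Cl)cc2)sc(C(=O)c2ccc(OC)cc2)c1C` gives "not active" (no number reported) in this assay, with no number reported.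

Compound 4 `COc1ccc(C(=O)c2sc(Nc3ccc(Cl)cc3)c(C(=O)O)c2C)cc1` differs from compound 3 by chloro in place of methoxy on an aromatic carbon. Among the compounds with values here, no measured step covers a chloro in place of a methoxy at this place; the only measured step, a number 8.7 percentage points lower from compound 2 to compound 3 (within the scatter), concerns a methoxy in place of a hydrogen and is within the scatter. Within the data shown here, compound 1 also carries the chloro at this place but differs from compound 4 elsewhere as well, and its report shows only that no number was obtained. Among the measured compounds shown here, with no measured step bearing directly on the change, a step of a number 0.5 percentage points higher from compound 3 to compound 4 (within the scatter) is expected, none beyond the scatter. Compound 4 is therefore estimated at 33% in this assay, in the range 12% to 54%, with some chance that, as for compound 1, no number is reported.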

Compound 4, a percentage reported as activity, at one concentration (the size of the read-out at that concentration, not a potency): "not active" (no number reported)
No number was reported for compound 4, and the estimate cannot be compared.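

Within the data shown here, compound 4 gives "not active" (no number reported) in this assay and so no step from compound 3 to compound 4 can be read. Nothing measured here accounts for this result. The compounds shown leave open whether the missing number for compound 1 and compound 4 goes with the (4-chlorophenyl)amino group they share.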